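The compounds below may be only part of what the source reports. "The series", "measured", "known", "first", "only" and "open" are said of these compounds alone.

Compound 1, `O=S(=O)(c1ccc(F)c(F)c1)c1cnc2c(F)cccc2c1-c1ccc(Cl)cc1`: 0.2 mL/min
Compound 2, `O=S(=O)(c1cc(F)cc(F)c1)c1cnc2cc(F)ccc2c1-c1cccc(F)c1`: 1.8 mL/min

Of the compounds shown here, two have so far been measured in an ADME assay on microsomes from liver (Rattus norvegicus) for metabolic stability, tested at 2.5 uM; a lower number here means slower removal, a higher number faster removal of the compound. Compound 1 gives 0.2 mL/min in this assay, and compound 2 gives 1.8 mL/min. Of the two numbers, compound 2 has the higher one, meaning it is removed faster by the liver preparation, and the gap between the two compounds is wider than the usual scatter of repeated measurements.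

Compound 3, `O=S(=O)(c1cc(Cl)cc(Cl)c1)c1cnc2cc(F)ccc2c1-c1cccc(F)c1`, has not yet been measured in this assay. It keeps the core of compound 2 and differs in one place: 3,5-dichlorophenyl in place of 3,5-difluorophenyl on a sulfonyl sulfur. The change puts 3,5-dichlorophenyl in place of 3,5-difluorophenyl on a sulfonyl sulfur. Going by the values given here, no measured pair shows this exchange, so there is no number to build on. The expectation for compound 3 is a small rise in the number, a step of a 1.2-fold higher number from compound 2 to compound 3 (0.09 log units; within the scatter), which may well stay inside the scatter. The estimate for compound 3 in this assay is 2.2 mL/min, with a range from 0.9 mL/min to 5 mL/min.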

Compound 3, intrinsic clearance in a liver preparation (reported as CLH), per the amount of preparation that the assay uses: 1.53 mL/min
Compound 3: the middle estimate sits 1.4-fold (0.16 log units) above what was measured; measured number inside the range.
By their numbers in this assay, from the lowest: compound 1; then compounds 3 and 2 (each within the scatter of the next).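

On a sulfonyl sulfur of this core, swapping 3,5-difluorophenyl for 3,5-dichlorophenyl gives, in this assay, a 1.2-fold lower number from compound 2 to compound 3 (0.07 log units; within the scatter), so this exchange leaves compound 2 and compound 3 indistinguishable in how fast the liver preparation removes them. Going by these compounds alone, this is the first direct reading at this position: the two compounds differ in one place only, so the comparison is clean, and at this position the two halogens, each present twice on the phenyl ring, can stand in for each other without a change that this assay can resolve. Nothing measured here explains why the exchange leaves the number within the scatter.

On these data alone, this single pair covers only two closely related halogenated phenyl rings, so it remains open whether the same tolerance would hold for a different kind of group on the sulfonyl sulfur, such as a phenyl ring carrying a methoxy group, a pyridine ring or a short alkyl chain. As far as these compounds go, it also remains open whether the same exchange would read the same way with other substituents on the shared core.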